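Swapping a dibromoethenyl chain end for a terminal alkyne

The compounds below may be only part of what the source reports. "The series", "measured", "known", "first", "only" and "open" are said of these compounds alone.

Measured compounds and their values:
- Compound 1, `C[C@H]1CC(Cl)=C([Si](C)(C)C)[C@@H](C2CCCCC2)O1`: 33000 nM
- Compound 2, `C[C@@H]1O[C@H](C2CCCCC2)C([Si](C)(C)C)=C(Cl)[C@H]1C`: 84000 nM
- Compound 3, `C[C@@H]1O[C@H](CCC=C(Br)Br)C([Si](C)(C)C)=C(Cl)[C@H]1C`: 90000 nM

In a functional assay on WiDr cells (Homo sapiens) for antiproliferative activity (a higher number here means a weaker inhibitor of growth, a lower number a stronger inhibitor of growth), compound 3 gives the highest of the three numbers, although compound 2 sits within the scatter of it, so the two cannot be ranked against each other. Compound 1 is the only one clearly apart, as shown by the step of a 2.5-fold higher number from compound 1 to compound 2 (0.41 log units; beyond the scatter).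

Compound 4, `C#CCC[C@H]1O[C@@H](C)[C@H](C)C(Cl)=C1[Si](C)(C)C`, differs from compound 3 by ethynyl in place of 2,2-dibromoethenyl on a saturated chain carbon, two bonds along the chain from a saturated ring carbon. Going by the values given here, no measured step alters this part of the chain, so the steps at hand bear only loosely on it. The closest is a 1.1-fold higher number from compound 2 to compound 3 (0.03 log units; within the scatter), in which the whole cyclohexyl group was exchanged for the dibromobutenyl chain with no change beyond the scatter, suggesting that this region tolerates variation without much effect on growth inhibition.

Accordingly, a step of no change at the digits printed from compound 3 to compound 4 (within the scatter) is expected for compound 4, with no clear direction. Compound 4 is therefore estimated to give 90000 nM, within a range from 30000 nM to 250000 nM.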

Compound 4, concentration for total growth inhibition: 68000 nM
Compound 4: middle estimate off by 1.3-fold (0.12 log units), on the high side, within the range that was stated.
By their numbers in this assay, from the lowest: compound 1; then compounds 4, 2 and 3 (each within the scatter of the next).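

In this assay, going by these compounds alone, this is the first change at the chain end itself: ethynyl in place of 2,2-dibromoethenyl gives a 1.3-fold lower number from compound 3 to compound 4 (0.12 log units; within the scatter) and so shows that both bromine atoms and the double bond can be given up with no shift beyond the scatter. Setting the new chain against the ring group, but-3-yn-1-yl in place of cyclohexyl on a saturated ring carbon gives a 1.2-fold lower number from compound 2 to compound 4 (0.09 log units; within the scatter) and adds a third group at this carbon that cannot be told apart from the other two. No measurement is available to explain why these groups read alike.

Going by these compounds, whether an amine or a carboxylic acid at the chain end, or a longer chain, would move the number beyond the scatter remains open. Also open, on these data alone, is whether the methyl step a 2.5-fold higher number from compound 1 to compound 2 (0.41 log units; beyond the scatter) would recur with either chain in place of cyclohexyl.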